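The compounds below may be only part of what the source reports. "The series", "measured", "known", "first", "only" and "open" are said of these compounds alone.

In a functional assay on UACC-62 cells (Homo sapiens) (a higher number here means a weaker inhibitor of growth, a lower number a stronger inhibitor of growth), the measured compounds stand as follows.
Compound 1 `O=S(=O)(/C=C/c1ccc(F)cc1F)Cc1ccc(Nc2ncnc3ccccc23)cc1` gives > 100000 nM, which is a limit of the assay and not a number.
Compound 2 `O=S(=O)(/C=C/c1ccc(F)cc1Cl)Cc1ccc(Nc2ncnc3ccccc23)cc1` gives 100000 nM.
Compound 3 `O=S(=O)(/C=C/c1ccc(F)cc1Cl)Cc1ccc(Nc2ncnc3cc(Cl)ccc23)cc1` gives 72000 nM.

Compound 2 and compound 3 carry the same side chain and differ in the core: chloro in place of hydrogen on an aromatic carbon. This change gives a 1.4-fold lower number from compound 2 to compound 3 (0.14 log units; within the scatter), so the two values sit together and neither stands apart from the other.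

Compound 2 and compound 1 share the same core and differ by fluoro in place of chloro on an aromatic carbon. On these data alone, the step reads a number no lower from compound 2 to compound 1 (the limit leaves the size open); its size stays open owing to the limit of > 100000 nM in this assay, at which 1 of the 3 values shown sits.

Compound 4 `O=S(=O)(/C=C/c1ccc(F)cc1F)Cc1ccc(Nc2ncnc3cc(Cl)ccc23)cc1` is not yet measured. It differs from compound 3 by fluoro in place of chloro on an aromatic carbon. The surroundings of the change are described in the same words as for the pair of compound 2 and compound 1, so it is the same change, here made on the core of compound 3 rather than on that of compound 2, the two cores differing as told by chloro in place of hydrogen on an aromatic carbon. The expected step for compound 4 is a 1.5-fold higher number from compound 3 to compound 4 (0.18 log units; within the scatter), set beside the earlier one; the expectation rests on that earlier step, because a number no lower from compound 2 to compound 1 (the limit leaves the size open) gave no lower number. For compound 4 the estimate is 110000 nM, with a range from 60000 nM to 200000 nM, and a considerable chance that this assay again reports only a limit.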

Compound 4, concentration for 50% growth inhibition: > 100000 nM
Compound 4: a limit, no number (the forecaster's own chance of this, stated with the estimate: 60%); the middle value is on the limit's open side.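

Working notes on the series: in this assay, the change from 2-chloro-4-fluorophenyl to 2,4-difluorophenyl, made on the chloro-bearing core, gives an at least 1.3-fold higher number from compound 3 to compound 4 (0.14 log units; that floor lies within the scatter), and that floor alone does not establish a real difference. Set beside the same change on the core without the added chloro, the comparison of the two steps stays unresolved: the same change on two cores in this assay, a number no lower (the limit leaves the size open) from compound 2 to compound 1 and an at least 1.3-fold higher number (0.14 log units; that floor lies within the scatter) from compound 3 to compound 4; the limit leaves it open whether they differ

On both cores the change gives no lower number, which is all that carries over, and neither the true size of either step nor any agreement in size is shown; the step between the two compounds at the limit cannot be read, and the measurements reach the top of the readable range: the limit of > 100000 nM in this assay, at which 2 of the 4 values shown sit.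

The compounds shown leave open whether any group other than chloro or fluoro at this place on the aromatic ring, such as a methoxy group, a nitrile or an amine, would give a number clear of that limit. They also leave open how a carboxylic acid or a longer chain in place of the 2-(2-chloro-4-fluorophenyl)ethenyl group would read in this assay.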